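The compounds below may be only part of what the source reports. "The series", "measured", "known", "first", "only" and "open" are said of these compounds alone.

Of the compounds shown here, three sharing one core have been tested so far in an ADME assay on HEK293 cells (Homo sapiens) for cytotoxicity, with a stated time of 72 h; a higher number here means that more compound is needed for the effect, a lower number that less compound is needed. Compound 1 `C=C[C@@](C)(/C=C/c1ccc(OCc2ccccc2)cc1)CCC=C(C)C` gives > 36600 nM, which is a limit of the assay and not a number. Compound 2 `C=C[C@@](C)(/C=C/c1ccc(O)cc1)CCC1OC1(C)C` gives > 36600 nM, which is again a limit. Compound 3 `C=C[C@@](C)(/C=C/c1ccc(O)cc1)CC/C=C/C(=O)c1ccccc1` gives > 36600 nM, also a limit. Together these readings amount to the limit of > 36600 nM in this assay, at which 3 of the 3 values shown sit, so compound 2 stands level with the other two at that limit and has no number of its own.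

Compound 4 `C=C[C@@](C)(/C=C/c1ccc(O)cc1)CC/C=C(\C)CO` has not yet been measured. It has the same atoms as compound 2, joined differently: 2-(hydroxymethyl)prop-1-en-1-yl in place of 3,3-dimethyloxiran-2-yl on a saturated chain carbon, three bonds along the chain from two double-bonded chain carbons. The ring of the 3,3-dimethyloxiran-2-yl group is gone, and an open 2-(hydroxymethyl)prop-1-en-1-yl group stands in its place on a saturated chain carbon.

Within the data shown here, no measured pair shows what a change like this does in this assay, so the expectation rests on the limit readings alone. Compound 2, the starting point, gives > 36600 nM, a limit. No step beyond the usual scatter is expected, and no direction is favoured. The estimated step is small, a step that the limit leaves unreadable from compound 2 to compound 4. For compound 4 the expected value is 40000 nM, with an estimated range from 20000 nM to 80000 nM.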

Compound 4, half-maximal effective concentration: > 36600 nM
Compound 4: no number, only a limit; the forecaster's own chance of this, stated with the estimate: 80%; the middle value is on the limit's open side.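

Compound 2 and compound 4 both carry only a limit and not a number, and no step can be read between them. All the compounds shown share the same reading: the limit of > 36600 nM in this assay, at which 4 of the 4 values shown sit.

The compounds shown leave open how much of any of them is needed for the effect in this assay.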